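Aryloxy variation on a shared core: estimate for compound 3

A few compounds are considered here, and "the series" means these few. Any claim that something is new, unique, unknown or untested is made for them only; others in the source may bear on it.

Measured compounds:
compound 1 `NC1=NC2(CCOCC2)N(OCCCOc2cccc(Cl)c2Cl)C(N)=N1`: 81.7%
compound 2 `NC1=NC2(CCOCC2)N(OCCCOc2ccccc2Br)C(N)=N1`: 83.8%

In an assay on isolated protein for inhibition of Dihydrofolate reductase (Homo sapiens), read by spectrophotometry, using NADPH, with stated times of 5 s and 6 min, tested at 5 uM (a higher number here means a stronger effect of the compound at the concentration tested, a lower number a weaker effect), compound 1 gives 81.7% and compound 2 gives 83.8%. The two lie within the scatter of each other: a number 2.1 percentage points higher from compound 1 to compound 2 (within the scatter). Compound 3 `NC1=NC2(CCOCC2)N(OCCCOc2ccc(Br)cc2)C(N)=N1` is not yet measured; it differs from compound 2 in the aryl on the ether oxygen: 4-bromophenyl in place of 2-bromophenyl on an oxygen on a saturated carbon. Going by the values given here, no measured step exchanges 2-bromophenyl for 4-bromophenyl; the only step known alters the halogen pattern on that ring and stays within the scatter. For compound 3 no step beyond the scatter is therefore expected in this assay, a number 3.8 percentage points lower from compound 2 to compound 3 (within the scatter), and its value is estimated at 80% within 65% to 92%.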

Compound 3, a percentage reported as inhibition, at one concentration (the size of the read-out at that concentration, not a potency): > 90%
Compound 3: only a limit was reported; the forecaster's own chance of this, stated with the estimate: 0%; at least 10 percentage points between middle value and limit.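

In this assay compound 3 gives > 90%, which is a limit and not a number. Keeping the atoms of the aryl group and changing only the place of the bromine, 4-bromophenyl in place of 2-bromophenyl, reads a number at least 6.2 percentage points higher from compound 2 to compound 3 (that floor lies within the scatter), while 4-bromophenyl in place of 2,3-dichlorophenyl reads a number at least 8.3 percentage points higher from compound 1 to compound 3 (that floor lies within the scatter). Neither floor establishes a gain, but the 4-bromophenyl group shows no loss on this ether oxygen.

On these data alone, how far compound 3 lies from the other two remains open. Also open, as far as these compounds go, is whether an amine or a carboxylic acid in place of the bromine, or a longer chain to the ether oxygen, would keep this read-out.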